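This account rests on a few compounds, and the source may have more. Where it says the series, first, only, none or still open, it means among the compounds named here.

Working notes on the series. All compounds share one core and differ only in the group on the carbonyl carbon attached to the ring nitrogen. Compound 1 `O=C(NC[C@@H]1[C@H]2CN(C(=O)/C=C/c3cc(Cl)cc(Cl)c3)C[C@@H]12)c1ccc2[nH]c(=O)oc2c1` carries the 2-(3,5-dichlorophenyl)ethenyl group; in a physicochemical assay for solubility, with a stated time of 24 h, at pH 6.8 (on this read-out higher numbers stand for higher solubility and lower numbers for lower solubility), compound 1 gives < 1 ug/mL, a limit of the assay rather than a number. Compound 2 `O=C(NC[C@@H]1[C@H]2CN(C(=O)CCc3cc(Cl)cc(Cl)c3)C[C@@H]12)c1ccc2[nH]c(=O)oc2c1` carries 2-(3,5-dichlorophenyl)ethyl in its place, and in this assay compound 2 gives < 1 ug/mL, again a limit. Compound 3 `O=C(NC[C@@H]1[C@H]2CN(C(=O)NCc3cc(Cl)cc(Cl)c3)C[C@@H]12)c1ccc2[nH]c(=O)oc2c1` carries (3,5-dichlorobenzyl)amino there, and in this assay compound 3 gives < 1 ug/mL, also a limit. The steps a step that the two limits leave unreadable from compound 1 to compound 2, a step that the two limits leave unreadable from compound 1 to compound 3 and a step that the two limits leave unreadable from compound 2 to compound 3 carry no readable size, since (the limit of < 1 ug/mL in this assay, at which 3 of the 3 values shown sit). Compound 3 thus stands at the shared limit, not above any other compound.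

Compound 4 `Cc1ccc(COC(=O)N2C[C@@H]3[C@@H](CNC(=O)c4ccc5[nH]c(=O)oc5c4)[C@@H]3C2)nc1` differs from compound 3 in one place: a group of 9 heavy atoms (7 carbon, 1 nitrogen, 1 oxygen; one six-membered aromatic ring with 1 hetero atom) in place of a group of 10 heavy atoms (7 carbon, 1 nitrogen, 2 chlorine; one six-membered aromatic ring of carbon only), on a carbonyl carbon. For the measured compounds named here, no measured step bears on a change of this kind, as every step in the set runs between two limits, so no size or direction can be read from them. Compound 4 is estimated at 5 ug/mL, with a range of 1 ug/mL to 30 ug/mL. The estimated step of an at least 5.0-fold higher number from compound 3 to compound 4 (0.69 log units; beyond the scatter) may still end at the limit.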

Compound 4, solubility: 56 ug/mL
Compound 4: the middle estimate sits 11-fold (1.05 log units) below what was measured; the whole stated range lies below it.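

Compared with the earlier compounds, the group on the carbonyl carbon now gives readable steps in this assay: an at least 56-fold higher number from compound 3 to compound 4 (1.74 log units; beyond the scatter), an at least 56-fold higher number from compound 2 to compound 4 (1.74 log units; beyond the scatter) and an at least 56-fold higher number from compound 1 to compound 4 (1.74 log units; beyond the scatter). For the compounds shown here, the three earlier groups left no difference to read, and the group with one six-membered aromatic ring with 1 hetero atom is the first here to come off the limit. Each step starts from a limit, so its full size stays unknown: the limit of < 1 ug/mL in this assay, at which 3 of the 4 values shown sit.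

The compounds shown do not separate the change of ring, the loss of the chlorines and the change of link to the carbonyl carbon, since compound 4 differs in all of these at once. A 3,5-dichlorobenzyloxy or an unsubstituted benzyloxy group in the same place would bear on that, and an amine on the ring would test how far the read-out can rise.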